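Bromo Substitution on a Dithiocarbamate Chalcone Amide

A few compounds are considered here, and "the series" means these few. Any claim that something is new, unique, unknown or untested is made for them only; others in the source may bear on it.

Compound 3 `O=C(CSC(=S)N[C@H]1CCOC1=O)Nc1ccc(C(=O)/C=C/c2ccccc2)cc1` stands as the weaker of the two compounds with a number in a functional assay on MCF7 cells (Homo sapiens) for cytotoxicity, read by MTT assay, with a stated time of 72 h (a higher number here means a weaker inhibitor, a lower number a stronger inhibitor), where compound 3 gives 44300 nM. Compound 2 `O=C(CCl)Nc1ccc(C(=O)/C=C/c2ccc(Br)cc2)cc1` gives 4640 nM in this assay. Compound 1 `CC(=O)c1ccc(NC(=O)CSC(=S)N[C@H]2CCOC2=O)cc1` gives only a limit in this assay, > 128000 nM. For the measured compounds named here, the single measured step, an at least 2.8-fold lower number from compound 1 to compound 3 (0.46 log units; beyond the scatter), concerns the carbonyl carbon rather than the outer aromatic ring. Compound 4 `O=C(CSC(=S)N[C@H]1CCOC1=O)Nc1ccc(C(=O)/C=C/c2ccc(Br)cc2)cc1` differs from compound 3 by bromo in place of hydrogen on an aromatic carbon. Going by the values given here, no measured pair isolates this bromo change; compound 2 carries the bromo but differs from compound 3 in a second place as well. A step of at most modest size, toward a lower number, is expected, a 1.5-fold lower number from compound 3 to compound 4 (0.17 log units; within the scatter). Compound 4 is therefore estimated at 30000 nM, with a range from 10000 nM to 90000 nM.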

Compound 4, half-maximal inhibitory concentration: 18700 nM
Estimate against measurement, compound 4: 1.6-fold (0.21 log units) above; the range from low to high includes it.
By their numbers in this assay, from the lowest: compound 2; then compound 4; then compound 3. At a limit, above all of these: compound 1.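

Bromo in place of hydrogen, on an aromatic carbon para to a large group, now has a measured effect of its own in this assay: a 2.4-fold lower number from compound 3 to compound 4 (0.37 log units; beyond the scatter). With the bromo present in both compounds, the group of 10 heavy atoms in place of one chlorine atom moves the number the other way, a 4.0-fold higher number from compound 2 to compound 4 (0.61 log units; beyond the scatter). The 2-(4-bromophenyl)ethenyl group in place of methyl gives an at least 6.8-fold lower number from compound 1 to compound 4 (0.83 log units; beyond the scatter), a step that rests on a limit: the limit of > 128000 nM in this assay, at which 1 of the 4 values shown sits.

On these data alone, whether chlorine, a methoxy group or a nitrile on that same aromatic carbon would give a similar step stays open. So does whether any other atom in place of hydrogen there would reach the number of the chlorine-bearing compound 2.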